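Changing the Amine on the Thiocarbonyl Carbon

The compounds below may be only part of what the source reports. "The series", "measured", "known", "first", "only" and "open" are said of these compounds alone.

Compound 1 `O=c1c(SC(=S)N2CCCCC2)coc2ccccc12`: 17400 nM
Compound 2 `O=c1c(CSC(=S)N2CCCCC2)coc2cc(Cl)ccc12`: 240 nM

In a functional assay on MDA-MB-435S cells (Homo sapiens) for antiproliferative activity, read by MTT assay, with a stated time of 72 h (on this read-out higher numbers stand for weaker inhibition and lower numbers for stronger inhibition), compound 1 gives 17400 nM, while compound 2 gives 240 nM, the lowest of the two numbers and well beyond the scatter from compound 1. Compound 3 `CC(C)N(C(=S)SCc1coc2cc(Cl)ccc2c1=O)C(C)C` differs from compound 2 by diisopropylamino in place of piperidin-1-yl on a thiocarbonyl carbon. Going by the values given here, no measured pair isolates this change, so the step in this assay is expected to be small, within the scatter or slightly toward weaker inhibition. The estimated step is a 1.7-fold higher number from compound 2 to compound 3 (0.22 log units; within the scatter). Compound 3 is expected to give about 400 nM, with a range from 120 nM to 1500 nM.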

Compound 3, half-maximal inhibitory concentration: > 25000 nM
Compound 3 ended at the assay's limit (the forecaster's own chance of this, stated with the estimate: 3%); middle value at least 62-fold (1.79 log units) away from the limit.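

In this assay compound 3 gives > 25000 nM as a limit of the assay and not a number. This shows that the amine on the thiocarbonyl carbon is not a silent position: diisopropylamino in place of piperidin-1-yl gives an at least 100-fold higher number from compound 2 to compound 3 (2.01 log units; beyond the scatter) and no closer reading of this large step is possible. The step itself rests on that limit: the limit of > 25000 nM in this assay, at which 1 of the 3 values shown sits.

On these data alone, whether pyrrolidin-1-yl, morpholin-4-yl or diethylamino on the same carbon would keep the number of compound 2 stays open. What separates the piperidin-1-yl compounds from the diisopropylamino compound beyond this single exchange also cannot be read from these values.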